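This account rests on a few compounds, and the source may have more. Where it says the series, first, only, none or still open, it means among the compounds named here.

Values so far in a functional assay on HeLa cells (Homo sapiens) for antiproliferative activity, read by MTT assay, with a stated time of 72 h (on this read-out lower numbers stand for stronger inhibition and higher numbers for weaker inhibition), are as follows.

- compound 1 `COc1cccc(Nc2nc3c(c(Oc4cccc(NC(=O)C=C(C)C)c4)n2)CSCC3)c1` gives 19100 nM
- compound 2 `C=CC(=O)Nc1cccc(Oc2nc(Nc3cccc(C#N)c3)nc3c2CSCC3)c1` gives 34900 nM
- compound 3 `CC/C=C/C(=O)Nc1cccc(Oc2nc(Nc3cccc(C#N)c3)nc3c2CSCC3)c1` gives 31800 nM
- compound 4 `CC(C)=CC(=O)Nc1cccc(Oc2nc(Nc3cccc(C#N)c3)nc3c2CSCC3)c1` has no value yet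

Compound 3 sits in one band with compound 1 and compound 2. All three numbers lie within the usual scatter of one another, so they cannot be ranked.

Compound 4 has 2-methylprop-1-en-1-yl in place of but-1-en-1-yl on a carbonyl carbon. Among the measured compounds shown here, the two compounds hold the same atoms, joined differently, and no measured pair tests this exact swap.

Two observations bear on it. For the measured compounds named here, one measured step concerns the same carbonyl carbon (a 1.1-fold lower number from compound 2 to compound 3 (0.04 log units; within the scatter)), and that exchange of vinyl for but-1-en-1-yl stayed within the scatter. Compound 1 also carries 2-methylprop-1-en-1-yl on a carbonyl carbon, though it is not identical elsewhere, and its value (19100 nM) falls in the same band.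

So no shift beyond the scatter is expected in this assay and no firm direction can be given. The expected step is small, an estimated 1.1-fold lower number from compound 3 to compound 4 (0.06 log units; within the scatter) that stays within the scatter. Compound 4 is expected at 28000 nM with an estimated span from 14000 nM to 55000 nM as its range.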

Compound 4, half-maximal inhibitory concentration: 29200 nM
For compound 4 the middle estimate is 1.0-fold (0.02 log units) below the measured one; low and high end bracket the measured number.
By their numbers in this assay, from the lowest: compounds 1, 4, 3 and 2 (each within the scatter of the next).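

In this assay, exchanging but-1-en-1-yl for 2-methylprop-1-en-1-yl on the carbonyl carbon rearranges the same atoms and gives a 1.1-fold lower number from compound 3 to compound 4 (0.04 log units; within the scatter), so this rearrangement does not move the number beyond the usual scatter. Against the smaller vinyl group the picture is the same, with a 1.2-fold lower number from compound 2 to compound 4 (0.08 log units; within the scatter), which means that vinyl, but-1-en-1-yl and 2-methylprop-1-en-1-yl at this position cannot be ranked in this assay. With 2-methylprop-1-en-1-yl held constant, a second place can also be read, since cyano in place of methoxy on an aromatic carbon gives a 1.5-fold higher number from compound 1 to compound 4 (0.18 log units; within the scatter), and that exchange also stays within the scatter.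

No measurement at hand offers an explanation for how closely these numbers agree. As far as these compounds go, it remains open whether a group of a different kind on this carbonyl carbon, such as a vinyl group carrying a dimethylamino chain, a carboxylic acid or a saturated ethyl group, would move the number beyond the scatter, and whether a fluorine or an amine in place of the cyano on the aromatic carbon would do so.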